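Stripping the Ethyl Group from the Anilino Ring

The source may report more compounds than this note shows. Statements on the series, on what has been measured and on what is new or still open speak of the compounds shown alone.

Of the compounds shown here, two built on one shared core have been measured in a functional assay for inhibition, with Homo sapiens as the target; on this read-out lower numbers stand for stronger inhibition and higher numbers for weaker inhibition. Compound 1 `Cc1cccc(Nc2nccc(-c3cc(C)oc3C)n2)c1` gives 28500 nM. Compound 2 `CCc1ccc(Nc2nccc(-c3cc(C)oc3C)n2)cc1` gives 19200 nM, the lowest of the two numbers, although its gap to compound 1 stays within the scatter of repeated measurements, so the two cannot be ranked against each other.

The step to compound 3 `Cc1cc(-c2ccnc(Nc3ccccc3)n2)c(C)o1` removes the chain altogether: hydrogen in place of ethyl on an aromatic carbon, the ethyl leaving an aromatic carbon of a six-membered aromatic ring of carbon only. Among the measured compounds shown here, no measured pair differs in exactly this way, so there is no measured step of this kind to lean on. Both measured numbers sit in a narrow band, and nothing in them shows what the ethyl contributes. A modest weakening is expected, most likely no larger than the scatter itself, with the step from compound 2 to compound 3 estimated at a 1.6-fold higher number from compound 2 to compound 3 (0.19 log units; within the scatter). Compound 3 is accordingly expected to give 30000 nM in this assay, with a plausible range from 10000 nM to 90000 nM.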

Compound 3, half-maximal inhibitory concentration: 2000 nM
Compound 3: the middle estimate sits 15-fold (1.18 log units) above what was measured, and the stated range ends above it.
By their numbers in this assay, from the lowest: compound 3; then compounds 2 and 1 (each within the scatter of the next).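

In this assay, the ethyl on an aromatic carbon, para to a large group, proves to be far from a silent substituent: hydrogen in its place gives a 9.6-fold lower number from compound 2 to compound 3 (0.98 log units; beyond the scatter). Hydrogen in place of the methyl on an aromatic carbon gives a 14-fold lower number from compound 1 to compound 3 (1.15 log units; beyond the scatter), so the two alkyl-bearing compounds, which could not be ranked against each other, both stand clearly apart from the anilino ring that carries neither group. Nothing available explains this gain on the unsubstituted ring.

The compounds shown leave open whether a methyl at the place the ethyl held would give a number nearer to compound 2 or to compound 3, and whether a longer chain such as propyl would move the number further in the same direction. They also leave open whether a group other than an alkyl chain, such as a fluorine, a methoxy or an amine, could sit on this ring and keep a number close to that of compound 3, 2000 nM.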